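The compounds below may be only part of what the source reports. "The series", "measured", "known", "first", "only" and "open" are said of these compounds alone.

Compound 1, `Brc1cn2ccnc2c(-c2ccc3ncn(C4CCCCC4)c3c2)n1`, gives 17.1% in a functional assay on SF-268 cells (Homo sapiens) for inhibition, read by sulforhodamine B assay, with a stated time of 48 h, tested at 10 uM; on this read-out lower numbers stand for less inhibition and higher numbers for more inhibition at the one concentration tested (going by the name of the read-out). Compound 2, `O=Cc1ccc(-c2cn3ccnc3c(-c3ccc4ncn(C5CCCCC5)c4c3)n2)cc1`, gives 27.1% in this assay.

For the measured compounds named here, of the two numbers measured so far, compound 2 carries the upper one, yet its only neighbour is compound 1, and the step of a number 10 percentage points higher from compound 1 to compound 2 (within the scatter) stays within the scatter, so the two compounds cannot be told apart on this read-out. Compound 3, `Fc1ccc(-c2cn3ccnc3c(-c3ccc4ncn(C5CCCCC5)c4c3)n2)cc1`, has not been measured. It differs from compound 2 by fluoro in place of formyl on an aromatic carbon; read one bond further out, the change is 4-formylphenyl to 4-fluorophenyl.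

Going by the values given here, no measured step swaps one group on that phenyl for another. Among the compounds with values here, the single step available, a number 10 percentage points higher from compound 1 to compound 2 (within the scatter), exchanges bromo for the whole 4-formylphenyl and itself remains within the scatter. Nothing in these two numbers therefore points to a shift in either direction, and the step of a number 4.1 percentage points lower from compound 2 to compound 3 (within the scatter) is expected to stay within the scatter. Compound 3 is accordingly estimated at 23% in this assay, with a range from 5% to 42%.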

Compound 3, a percentage reported as inhibition, at one concentration (the size of the read-out at that concentration, not a potency): 10.7%
For compound 3 the middle estimate is 12.3 percentage points above the measured one; the measured number falls inside the stated range.
By their numbers in this assay, from the lowest: compounds 3, 1 and 2 (each within the scatter of the next, the first and the last beyond it).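

In this assay, for the compounds shown here, the exchange of formyl for fluoro on the same phenyl ring gives the first step to clear the scatter: a number 16.4 percentage points lower from compound 2 to compound 3 (beyond the scatter). It is a modest step, but it shows that the group on this aromatic carbon can register on this read-out, which the comparison of compound 1 with compound 2 could not show. Set against the bromo of compound 1, the 4-fluorophenyl group gives a number 6.4 percentage points lower from compound 1 to compound 3 (within the scatter), so placing a phenyl ring at that position does not by itself separate a compound from compound 1, and only compound 2 and compound 3 can be told apart; nothing at hand explains why these two differ.

The compounds shown leave open whether an amine or a carboxylic acid in the same place on the phenyl ring would read like the formyl of compound 2 or like the fluoro of compound 3. From the compounds shown here alone, they also share the cyclohexyl group throughout, so what a longer chain there would do to this small difference remains unknown.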